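Swapping an aminophenyl for a methoxycarbonylmethyl group

The source may hold more compounds than are shown below. What is called first, only, known or untested is meant among the compounds shown, and "the series" means these compounds.

Three compounds built on a shared core are on record. Compound 1 `CS(=O)(=O)Oc1c(C(=O)NCc2ccc(F)cc2)nc(Br)c2cccnc12` and compound 3 `C[C@H](CO)Nc1nc(C(=O)NCc2ccc(F)cc2)c(O)c2ncccc12` were each tested in a functional assay on MCF7 cells (Homo sapiens) for cytotoxicity, read by MTT assay, with a stated time of 72 h (a higher number here means a weaker inhibitor, a lower number a stronger inhibitor), without a result being reported: for compound 1 the entry reads "not determined" (no result reported) and for compound 3 it reads "not determined" (no result reported). For the measured compounds named here, that leaves compound 2 `Nc1ccc(Nc2c(C(=O)NCc3ccc(F)cc3)nc(Br)c3cccnc23)cc1` as the only compound with a number; in this assay compound 2 gives 4000 nM, so it stands alone with nothing to compare it against.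

Compound 4 `COC(=O)CNc1c(C(=O)NCc2ccc(F)cc2)nc(Br)c2cccnc12` has not yet been measured. It differs from compound 2 in a single place: (methoxycarbonyl)methyl in place of 4-aminophenyl on a nitrogen on an aromatic ring. Going by the values given here, no step between two measured compounds is available, so there is no guide to how large a change of this kind should be. Such a swap is expected to move the number by a modest step toward a weaker inhibitor, in a 1.8-fold higher number from compound 2 to compound 4 (0.24 log units; within the scatter), though a result within the scatter would not surprise. Compound 4 is therefore estimated at 7000 nM, with a range from 1500 nM to 30000 nM.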

Compound 4, half-maximal inhibitory concentration: > 10000 nM
Compound 4: a limit, no number; the forecaster's own chance of this, stated with the estimate: 20%; middle value at least 1.4-fold (0.15 log units) from the limit.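

For the compounds shown here, this is the first comparison available at this position: on a nitrogen on an aromatic ring, (methoxycarbonyl)methyl in place of 4-aminophenyl gives an at least 2.5-fold higher number from compound 2 to compound 4 (0.39 log units; beyond the scatter). In this assay compound 4 gives > 10000 nM, which is a limit of the assay and not a number. The change therefore makes for a weaker inhibitor by more than the scatter, but the step is only a minimum and its full size stays unknown: the limit of > 10000 nM in this assay, at which 1 of the 4 values shown sits.

The swap removes a six-membered aromatic ring and brings in a chain carrying a methyl ester in a single step, so the compounds shown leave open which of the two counts. A plain phenyl group, or a carboxylic acid in place of the methyl ester, would help to separate them.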